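The source may hold more compounds than are shown below. What is called first, only, known or untested is meant among the compounds shown, and "the series" means these compounds.

Measured compounds:
compound 1 `O=C1C=C(NCc2ccccc2)C(=O)c2c1nc1n2[C@H]2OC[C@@H](O)[C@H]2OC1`, a functional assay on ECa-109 cells for inhibition, with ECa-109 cell line (Homo sapiens) as the target, read by sulforhodamine B assay; a higher number here means a weaker inhibitor, a lower number a stronger inhibitor: > 8000 nM
compound 2 `O=C1C(Nc2ccc(Br)cc2)=CC(=O)c2c1nc1n2[C@H]2OC[C@@H](O)[C@H]2OC1`, this assay: 1980 nM

In this assay compound 1 reaches only a limit, > 8000 nM, so its number is not known beyond that bound. This is where compound 1 stands on the numbers shown: the limit of > 8000 nM in this assay, at which 1 of the 2 values shown sits. Compound 2 gives 1980 nM in this assay, a plain number rather than a limit.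

Compound 3 `O=C1C=C(Nc2ccc(C(F)(F)F)cc2)C(=O)c2c1nc1n2[C@H]2OC[C@@H](O)[C@H]2OC1` differs from compound 1 in one place: 4-(trifluoromethyl)phenyl in place of benzyl on an amine nitrogen. Compound 2 also carries a substituted phenyl on the amine nitrogen, and its value is the nearest guide for compound 3. From that guide, the expected step of an at least 3.2-fold lower number from compound 1 to compound 3 (0.50 log units; beyond the scatter) is a gain in potency beyond the usual scatter, with a fair chance the assay again reports only a limit. Compound 3 is therefore estimated at 2500 nM in this assay, within a range from 800 nM to 8000 nM.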

Compound 3, half-maximal inhibitory concentration: 5500 nM
For compound 3 the middle estimate is 2.2-fold (0.34 log units) below the measured one, and the stated range covers the measured number.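

Moving from benzyl to 4-(trifluoromethyl)phenyl on the amine nitrogen gives a plain number in this assay, and the step reads as an at least 1.4-fold lower number from compound 1 to compound 3 (0.16 log units; that floor lies within the scatter). So this position tolerates an aryl group directly on the nitrogen without loss, but the data do not show a gain beyond the scatter. The step rests on a limit for compound 1, not on a number: the limit of > 8000 nM in this assay, at which 1 of the 3 values shown sits.

As far as these compounds go, how large the step really is stays open, and compound 2 differs from compound 3 in more than one place, so it cannot settle the effect of the group on the phenyl ring. Also open, from the compounds shown here alone, is what an unsubstituted phenyl, or a methoxy or nitrile in place of the trifluoromethyl, would give on this amine nitrogen.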